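This account rests on a few compounds, and the source may have more. Where it says the series, first, only, none or still open, it means among the compounds named here.

Measured compounds:
- compound 1, `CCOC(=O)c1cnn(CC(C)O)c1NC(=O)Nc1cccc(F)c1`: > 10 nM
- compound 2, `CCOC(=O)c1cnn(C)c1NC(=O)NC(C)C`: 77 nM

The series is followed in a functional assay on cells (Neutrophil, Homo sapiens) for inhibition, with a stated time of 10 min; a lower number here means a stronger inhibitor, a higher number a weaker inhibitor. Going by the values given here, for compound 1 only a limit is known, > 10 nM, so its place on the scale is open; it is the one value among the two that sits at the limit of > 10 nM in this assay, at which 1 of the 2 values shown sits. In this assay, among the compounds with values here, compound 2 gives 77 nM, a number rather than a limit, though compound 2 differs from compound 1 in more than one place, so no single step between them can be read.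

The unmeasured compound 3, `CCOC(=O)c1cnn(CC(C)O)c1NC(=O)Nc1ccccc1F`, is the analogue of compound 1 in which the change is 2-fluorophenyl in place of 3-fluorophenyl on an amide-type nitrogen. Within the data shown here, no measured step of this kind is available. The expected step from compound 1 to compound 3 is a step that the limit leaves unreadable from compound 1 to compound 3, which is meant as no change beyond the usual scatter, in either direction. With compound 1 known only as a limit, compound 3 is estimated at 150 nM in this assay, within a range from 20 nM to 1500 nM, and a further limit-only result is itself a real possibility.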

Compound 3, half-maximal inhibitory concentration: 100 nM
Estimate against measurement, compound 3: 1.5-fold (0.18 log units) above; the range from low to high includes it.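

No step can be read from compound 1 to compound 3 in this assay, because the value of compound 1 is a limit and not a number: the limit of > 10 nM in this assay, at which 1 of the 3 values shown sits. The compounds shown leave open whether 2-fluorophenyl and 3-fluorophenyl on an amide-type nitrogen differ at all in this assay.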